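Swapping a para substituent on a weak antiproliferative series

This account rests on a few compounds, and the source may have more. Where it says the series, first, only, none or still open, it means among the compounds named here.

Measured so far in a functional assay on A549 cells (Homo sapiens) for antiproliferative activity, read by MTT assay; a higher number here means a weaker inhibitor, a lower number a stronger inhibitor:
compound 1, `C#CCN(c1nc2ccc(F)cc2s1)c1nc2ccc(OC)cc2s1`, gives 24500 nM
compound 2, `COc1ccc2nc(N(Cc3cc(-c4ccc(SC(F)(F)F)cc4)no3)c3nc4ccc(F)cc4s3)sc2c1`, gives 26500 nM
compound 3, `COc1ccc(-c2cc(CN(c3nc4ccc(F)cc4s3)c3nc4ccc(OC)cc4s3)on2)cc1`, gives 38800 nM

All three compounds share one core and differ only in the arm attached to the central nitrogen. Compound 3 sits within the usual scatter of both compound 1 and compound 2, so its number cannot be told apart from theirs; the three compounds are all weak inhibitors.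

Compound 4, `COc1ccc2nc(N(Cc3cc(-c4ccc(Br)cc4)no3)c3nc4ccc(F)cc4s3)sc2c1`, is compound 3 with one change: bromo in place of methoxy on an aromatic carbon. Among the compounds with values here, the only measured step that touches this same position is the one from compound 2 to compound 3, a 1.5-fold higher number from compound 2 to compound 3 (0.17 log units; within the scatter), where one group was exchanged for another on that carbon and the number barely moved. A further exchange at the same spot is therefore expected to give no step beyond the scatter in this assay, in either direction. The step from compound 3 to compound 4 is estimated as a 1.3-fold lower number from compound 3 to compound 4 (0.11 log units; within the scatter). Compound 4 is expected to give about 30000 nM, with a plausible range from 12000 nM to 80000 nM.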

Compound 4, half-maximal inhibitory concentration: 32700 nM
Compound 4: middle estimate off by 1.1-fold (0.04 log units), on the low side, within the range that was stated.
By their numbers in this assay, from the lowest: compounds 1, 2, 4 and 3 (each within the scatter of the next).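

In this assay the exchange of 4-methoxyphenyl for 4-bromophenyl gives a 1.2-fold lower number from compound 3 to compound 4 (0.07 log units; within the scatter) and the exchange of (trifluoromethyl)sulfanyl for bromo gives a 1.2-fold higher number from compound 2 to compound 4 (0.09 log units; within the scatter) on the same aromatic carbon. Within the data shown here, compounds 2, 3 and 4 therefore carry three different groups at this position, including a single bromine atom in place of the two heavy atoms of methoxy, and no step among them lies beyond the scatter. Nothing available on these compounds accounts for this flat result.

Going by these compounds, whether a group of another kind here, such as an amine or a carboxylic acid, would give a step beyond the scatter remains open. On these data alone, compounds 2, 3 and 4 also all keep the fluoro and methoxy groups on the shared core, so the effect of exchanging those groups is unknown as well.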